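The source may hold more compounds than are shown below. What is called first, only, known or untested is meant among the compounds shown, and "the series" means these compounds.

In an assay on cells for inhibition of sodium channel protein type 3 subunit alpha (Homo sapiens), read by electrophysiology (on this read-out higher numbers stand for weaker inhibition and lower numbers for stronger inhibition), the three measured compounds share one core and differ only in the ring on the sulfonamide nitrogen. Compound 1 `O=C(NCc1ccc(OC(F)(F)F)c(Cl)c1)c1ccc(S(=O)(=O)Nc2nccs2)c(F)c1` gives 11 nM, and compound 2 `O=C(NCc1ccc(OC(F)(F)F)c(Cl)c1)c1ccc(S(=O)(=O)Nc2ncns2)c(F)c1` gives 13 nM; the step of a 1.2-fold higher number from compound 1 to compound 2 (0.07 log units; within the scatter) lies within the scatter. Compound 3 `O=C(NCc1ccc(OC(F)(F)F)c(Cl)c1)c1ccc(S(=O)(=O)Nc2ncc(F)cn2)c(F)c1` gives 993 nM, the highest number of the three: the steps of a 90-fold higher number from compound 1 to compound 3 (1.96 log units; beyond the scatter) and a 76-fold higher number from compound 2 to compound 3 (1.88 log units; beyond the scatter) are both large and beyond the scatter, so compound 3 is the weakest inhibitor among the measured set.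

Compound 4 `O=C(NCc1ccc(OC(F)(F)F)c(Cl)c1)c1ccc(S(=O)(=O)Nc2ncccn2)c(F)c1` differs from compound 3 only by hydrogen in place of fluoro on an aromatic carbon. Among the measured compounds shown here, neither measured step speaks to this change: the two large steps to compound 3 exchange a five-membered ring for the fluoropyrimidine, and no pair shows the fluoro leaving while the six-membered ring stays. The pyrimidine ring remains in compound 4, and the measured steps give no ground to expect a return toward compound 1 or compound 2. Compound 4 is therefore expected to stay close to compound 3, with an expected step of a 1.2-fold lower number from compound 3 to compound 4 (0.09 log units; within the scatter) that may fall within the scatter. The estimate for compound 4 in this assay is 800 nM, within a range from 250 nM to 2500 nM.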

Compound 4, half-maximal inhibitory concentration: 374 nM
For compound 4 the middle estimate is 2.1-fold (0.33 log units) above the measured one, within the range that was stated.
By their numbers in this assay, from the lowest: compounds 1 and 2 (each within the scatter of the next); then compound 4; then compound 3.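

In this assay, hydrogen in place of fluoro is the first change shown that leaves the six-membered ring intact, and it gives a 2.7-fold lower number from compound 3 to compound 4 (0.42 log units; beyond the scatter), a modest step but one beyond the scatter. This shows that the aromatic carbon para to a large group, two atoms from the ring nitrogen, affects the read-out even when the change is a single fluorine atom. The pyrimidin-2-yl group still stands far from both five-membered rings, with a 29-fold higher number from compound 2 to compound 4 (1.46 log units; beyond the scatter) and a 34-fold higher number from compound 1 to compound 4 (1.53 log units; beyond the scatter) both large, so losing the fluoro recovers only part of the distance, and nothing measured here explains either the modest step or the large ones.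

The compounds shown hold only fluoro and hydrogen at this position, so it remains open how a chloro, methyl, methoxy or amino group there would read. On these data alone, it is also open whether a pyridin-2-yl or pyrazin-2-yl group on the sulfonamide nitrogen would stand nearer the pyrimidin-2-yl group or nearer the 1,3-thiazol-2-yl and 1,2,4-thiadiazol-5-yl groups.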